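Removing the trifluoromethyl group from compound 2

The source may report more compounds than this note shows. Statements on the series, on what has been measured and on what is new or still open speak of the compounds shown alone.

Compound 1 `O=C(CCCCC(S)CCS)Nc1ccccc1` and compound 2 `O=C(CCCCC(S)CCS)Nc1ccc([N+](=O)[O-])c(C(F)(F)F)c1` share one core and were tested in a functional assay on Bel-7402 cells (Homo sapiens) for inhibition, read by MTT assay, with a stated time of 24 h, tested at 0.1 ug/mL; a lower number here means less inhibition of growth, a higher number more inhibition of growth at the concentration tested. In this assay compound 1 gives 0.85% and compound 2 gives 6.54%. Compound 2 therefore stands level with compound 1 within the usual scatter, and both numbers are small. Compound 3 `O=C(CCCCC(S)CCS)Nc1ccc([N+](=O)[O-])cc1` has not yet been measured. It departs from compound 2 in one place: hydrogen in place of trifluoromethyl on an aromatic carbon. Going by the values given here, no step between measured compounds is available to size this change. With compound 1 at 0.85% and compound 2 at 6.54%, no change beyond the scatter is expected in this assay, in either direction. The estimated step of a number 2.5 percentage points lower from compound 2 to compound 3 (within the scatter) is accordingly expected to be small. For compound 3 the estimated value is 4%, with an expected range of -3% to 13%.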

Compound 3, percent growth inhibition at one concentration: 1.88%
The estimate for compound 3 lay 2.1 percentage points above the measured number; the range from low to high includes it.
By their numbers in this assay, from the lowest: compounds 1, 3 and 2 (each within the scatter of the next).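

In this assay the trifluoromethyl group on this aromatic carbon, ortho to a nitro group, can now be sized: hydrogen in its place gives a number 4.7 percentage points lower from compound 2 to compound 3 (within the scatter) on the shared core. The nitro group can be sized as well, and nitro in place of hydrogen gives a number 1 percentage points higher from compound 1 to compound 3 (within the scatter) in the same assay. Neither single replacement therefore separates these compounds at the concentration tested, and no measurement is at hand that would explain the numbers.

The compounds shown leave open whether an amine or a carboxylic acid on this aromatic carbon would give a number beyond the scatter. They also leave open whether a longer chain in place of the shared dithiol chain would do so.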